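Swapping Methyl for Chloro on Compound 2

A few compounds are considered here, and "the series" means these few. Any claim that something is new, unique, unknown or untested is made for them only; others in the source may bear on it.

In a functional assay on LS174T cells (Homo sapiens) for inhibition, read by MTT assay, with a stated time of 72 h (a higher number here means a weaker inhibitor, a lower number a stronger inhibitor), compound 1 `CC(C)c1ccc(C(=O)/C=C/C(=O)O)c(C(C)C)c1` gives 5360 nM and compound 2 `Cc1ccc(C(=O)/C=C/C(=O)O)c(Cl)c1` gives 27700 nM as its reading. Compound 2 thus holds the higher of the two numbers, which makes it the weaker inhibitor of this pair, and the gap between them lies beyond the usual scatter of repeated measurements. Compound 3 `O=C(O)/C=C/C(=O)c1ccc(Cl)cc1Cl` differs from compound 2 in a single place (chloro in place of methyl on an aromatic carbon) and the counted change is chloro in place of methyl on an aromatic carbon with the rest of the structure untouched. For the measured compounds named here, no measured pair yet shows what such a swap does in this assay so any expectation here is tentative. One single heavy atom replaces another, so only a small shift is expected. The expected step of a 1.4-fold lower number from compound 2 to compound 3 (0.14 log units; within the scatter) is a slightly lower number, within the scatter. Compound 3 is estimated at 20000 nM (expected range 9000 nM to 45000 nM).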

Compound 3, half-maximal inhibitory concentration: > 100000 nM
Compound 3 was reported as a limit; the forecaster's own chance of this, stated with the estimate: 5%; middle value at least 5.0-fold (0.69 log units) away from the limit.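

In this assay, compound 3 reads > 100000 nM, which is a limit of the assay and not a number. For the compounds shown here, this is the first measured swap of chloro in place of methyl on this aromatic carbon, meta to a chloro group and para to a group of 7 heavy atoms, and it gives an at least 3.6-fold higher number from compound 2 to compound 3 (0.55 log units; beyond the scatter), so replacing one heavy atom with another at this place is enough to make a clear difference to the reading. How far the step truly reaches cannot be told because compound 3 stands at a limit: the limit of > 100000 nM in this assay, at which 1 of the 3 values shown sits.

The compounds shown cannot tell whether the weaker reading comes from chloro arriving or from methyl leaving. A methoxy group or an amine at this same place would help to separate the two, by showing whether methyl is special here or chloro is the exception.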